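This account rests on a few compounds, and the source may have more. Where it says the series, first, only, none or still open, it means among the compounds named here.

Working notes on the series. Compound 1 `COc1ccc(NS(=O)(=O)/C=C/c2c(OC)cc(OCCCC(=O)O)cc2OC)cc1[N+](=O)[O-]` and compound 2 `COc1ccc(NS(=O)(=O)/C=C/c2c(OC)cc(OCCCC(=O)O)cc2OC)cc1N` differ at one aromatic carbon only. In a functional assay on K562 cells (Homo sapiens) for cytotoxicity, read by trypan blue exclusion, with a stated time of 96 h (a higher number here means a weaker inhibitor, a lower number a stronger inhibitor), compound 1 gives 100000 nM and compound 2 gives 10000 nM as the half-maximal inhibitory concentration. Compound 2 therefore holds the lower of the two numbers. Among the measured compounds shown here, the gap between them, a 10-fold lower number from compound 1 to compound 2 (1.00 log units; beyond the scatter) with amino in place of nitro, lies beyond the scatter and is the only measured step available.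

The same aromatic carbon changes again in compound 3 `COc1ccc(NS(=O)(=O)/C=C/c2c(OC)cc(OCCCC(=O)O)cc2OC)cc1O` with hydroxy in place of amino on an aromatic carbon as the counted difference. This places hydroxy in place of amino, ortho to a methoxy group and meta to a large group. For the measured compounds named here, the measured step shows that a change at this carbon can move the number, but no measured pair includes hydroxy, so its size carries over only loosely.

The expectation in this assay is a small move toward a higher number, estimated as a 2.0-fold higher number from compound 2 to compound 3 (0.30 log units; within the scatter) and possibly no step beyond the scatter. For compound 3 the estimate is 20000 nM with 5000 nM to 100000 nM as the expected range.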

Compound 3, half-maximal inhibitory concentration: 10000 nM
Estimate against measurement, compound 3: 2.0-fold (0.30 log units) above; the measured number falls inside the stated range.
By their numbers in this assay, from the lowest: compounds 2 and 3 (each within the scatter of the next); then compound 1.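

In this assay the step of no change at the digits printed from compound 2 to compound 3 (within the scatter) shows that hydroxy and amino are not told apart at this aromatic carbon, ortho to a methoxy group, so the lower number of compound 2 does not depend on amino alone. The step of a 10-fold lower number from compound 1 to compound 3 (1.00 log units; beyond the scatter) has the same printed size as a 10-fold lower number from compound 1 to compound 2 (1.00 log units; beyond the scatter) and shows that the earlier gap is not unique to amino: both replacements of nitro lead to a lower number, which leaves compound 1 as the weakest of the three in this assay. Nothing at hand gives a reason for the separation of nitro from amino and hydroxy, or for the match between those two groups.

Whether a methylamino, acetamido or fluoro group at this aromatic carbon would stay with compound 2 and compound 3 or move toward compound 1 remains open, since only three groups are shown there. On these data alone, it is equally open whether the same order of nitro, amino and hydroxy would hold with a methyl ester or a primary amide in place of the carboxylic acid.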